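Methyl on the chain carbon: two pairs in the series

A few compounds are considered here, and "the series" means these few. Any claim that something is new, unique, unknown or untested is made for them only; others in the source may bear on it.

Compound 1 `O=C1/C(=C\c2ccccn2)c2ccccc2N1Cc1ccccc1` gives 24.7% in a functional assay on HL-60 cells (Homo sapiens) for cytotoxicity, read by MTT assay, with a stated time of 72 h, tested at 5 uM; a lower number here means a stronger effect, a higher number a weaker effect of the compound at the concentration tested. Compound 2 `CC(c1ccccc1)N1C(=O)/C(=C\c2ccccn2)c2ccccc21` gives 55.7% in this assay, and the step between them is a number 31 percentage points higher from compound 1 to compound 2 (beyond the scatter) for the change (methyl in place of hydrogen on a saturated chain carbon bound to an amide-type nitrogen in a ring and an aromatic carbon). Compound 3 `O=C1/C(=C\c2ccc3ccccc3n2)c2ccccc2N1Cc1ccccc1` gives 12.2% in this assay, the lowest number of the three measured compounds; its nearest neighbour is compound 1 and its furthest is compound 2. The difference between the cores of compound 3 and compound 1 is not broken down here.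

Compound 4 `CC(c1ccccc1)N1C(=O)/C(=C\c2ccc3ccccc3n2)c2ccccc21` has not been measured in this assay. It differs from compound 3 by methyl in place of hydrogen on a saturated chain carbon bound to an amide-type nitrogen in a ring and an aromatic carbon, the same kind of change that turns compound 1 into compound 2, at a place worded the same in both pairs. Within the compounds shown this change occurs twice, once measured and once open. Going by the values given here, the only measured instance, from compound 1 to compound 2, gave a large rise in the number. With a single precedent the expectation rests on that one step alone, and the core of compound 3 may not carry the change the same way, so the range is kept wide. The expected step from compound 3 to compound 4 is therefore a number 25.8 percentage points higher from compound 3 to compound 4 (beyond the scatter), set somewhat smaller than the measured step because a number 31 percentage points higher from compound 1 to compound 2 (beyond the scatter) is only one observation on a different core. Compound 4 is estimated to give 38% in this assay, with a range from 18% to 60%.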

Compound 4, a percentage reported as activity, at one concentration (the size of the read-out at that concentration, not a potency): 18.5%
Estimate against measurement, compound 4: 19.5 percentage points above; the measured number falls inside the stated range.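

In this assay the change from benzyl to 1-phenylethyl on the core of compound 3 gives a number 6.3 percentage points higher from compound 3 to compound 4 (within the scatter), a step that cannot be told apart from the usual scatter of this read-out, whereas the same change on the core of compound 1 gives a large step, a number 31 percentage points higher from compound 1 to compound 2 (beyond the scatter). The two pairs therefore do not agree, and the size of the step seen on one core cannot be carried over to the other: the same change on two cores in this assay, a number 31 percentage points higher (beyond the scatter) from compound 1 to compound 2 and a number 6.3 percentage points higher (within the scatter) from compound 3 to compound 4, 24.7 percentage points apart, beyond the scatter of two such steps This rests on a single pair per core at a single concentration, so it shows that the outcome of the change differs between these two cores, but it does not show which feature of the cores accounts for the difference, nor how the change would run on any further core in the series.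

The compounds shown leave open whether ethyl, a longer chain or a hydroxymethyl group in place of the methyl on the saturated chain carbon would follow the pattern of compound 2 or that of compound 4. They also leave open whether an amine or a carboxylic acid on the phenyl ring of the benzyl group would separate the two cores in the same way.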